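This account rests on a few compounds, and the source may have more. Where it says the series, first, only, none or still open, it means among the compounds named here.

The series shares one core, seen in compound 1 `COc1ccccc1C(=O)NCc1ccc(CNS(=O)(=O)c2cccc(C)c2)cc1`, compound 2 `O=C(NCc1ccc(CNS(=O)(=O)c2cccc(F)c2)cc1)c1cccnc1` and compound 3 `COc1ccccc1C(=O)NCc1ccc(CNS(=O)(=O)c2cccc(F)c2)cc1`. In an assay on MDA-MB-231 cells for displacement of a labelled ligand from C-X-C chemokine receptor type 4 (Homo sapiens), read by fluorescence and microscopy, with stated times of 10 min and 30 min (on this read-out lower numbers stand for an effect already at smaller amounts and higher numbers for an effect only at larger amounts of compound), compound 1 gives 1000 nM, compound 2 gives 1000 nM and compound 3 gives 1000 nM. Both steps measured so far are flat: no change at the digits printed from compound 1 to compound 3 (within the scatter), and no change at the digits printed from compound 2 to compound 3 (within the scatter). Compound 3 therefore stands level with compounds 1 and 2 on the numbers shown, and none of the three can be called stronger or weaker than another.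

Compound 4 `COc1ccccc1C(=O)NCc1ccc(CNS(=O)(=O)c2ccccc2C)cc1` is not yet measured. Its difference from compound 3 is 2-methylphenyl in place of 3-fluorophenyl on a sulfonyl sulfur. For the measured compounds named here, of the measured steps, no change at the digits printed from compound 1 to compound 3 (within the scatter) is the one that touches the group on the sulfonyl sulfur, and it was flat; no change at the digits printed from compound 2 to compound 3 (within the scatter) changes the group on the carbonyl carbon and was flat as well. Going by the values given here, nothing in the measured pairs shows the read-out moving with the group on the sulfonyl sulfur, and no measured pair tests 2-methylphenyl itself, so the expectation rests on the flat steps alone. The step expected is therefore none beyond the scatter: no change at the digits printed from compound 3 to compound 4 (within the scatter). Compound 4 is estimated at 1000 nM in this assay, with a range from 500 nM to 2000 nM.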

Compound 4, effective concentration (reported as EC, without a stated level of effect): 1000 nM
Compound 4: the middle estimate sits on the measured number at the digits printed, and the stated range covers the measured number.
By their numbers in this assay, from the lowest: compounds 1, 2, 3 and 4 (each within the scatter of the next).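

In this assay, the group on the sulfonyl sulfur now tolerates a change of both substituent and ring position at once: 2-methylphenyl in place of 3-fluorophenyl gives no change at the digits printed from compound 3 to compound 4 (within the scatter). For the compounds shown here, the second pair is the first to keep the substituent and differ only in its place on the ring, and 2-methylphenyl in place of 3-methylphenyl gives no change at the digits printed from compound 1 to compound 4 (within the scatter), so 3-fluorophenyl, 3-methylphenyl and 2-methylphenyl on the sulfonyl sulfur all read alike on the 2-methoxyphenyl amide. No measurement at hand accounts for this flat response.

The compounds shown leave open whether a ring carrying an amine or a carboxylic acid, or a longer alkyl chain in place of the ring on the sulfonyl sulfur, would move the read-out at all. Also open, as far as these compounds go, is whether 2-methylphenyl on the sulfonyl sulfur stays level when pyridin-3-yl replaces 2-methoxyphenyl on the carbonyl carbon.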